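The source may hold more compounds than are shown below. What is called first, only, known or untested is meant among the compounds shown, and "the series" means these compounds.

In a functional assay on MGC-803 cells (Homo sapiens) for inhibition, read by sulforhodamine B assay (on this read-out higher numbers stand for weaker inhibition and lower numbers for stronger inhibition), compound 1 `Cc1ccc(NC2=CC(=O)c3c(nc4n3[C@H]3OC[C@@H](O)[C@H]3OC4)C2=O)cc1` gives 1550 nM and compound 2 `O=C1C=C(Nc2ccc(Br)cc2)C(=O)c2c1nc1n2[C@H]2OC[C@@H](O)[C@H]2OC1` gives 1010 nM, so the two values lie within the scatter of each other. Compound 3 `O=C1C(NC2CC2)=CC(=O)c2c1nc1n2[C@H]2OC[C@@H](O)[C@H]2OC1` carries cyclopropyl in place of 4-methylphenyl on an amine nitrogen. Among the measured compounds shown here, no measured pair shows this change, so the expectation is loose: a modest step towards a higher number, meaning weaker inhibition, in this assay. The expected step is a 1.9-fold higher number from compound 1 to compound 3 (0.29 log units; within the scatter). Compound 3 is estimated at 3000 nM, with an expected range of 900 nM to 10000 nM.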

Compound 3, half-maximal inhibitory concentration: > 4000 nM
Compound 3: only a limit was reported; the forecaster's own chance of this, stated with the estimate: 10%; middle value at least 1.3-fold (0.12 log units) away from the limit.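

Cyclopropyl in place of 4-methylphenyl on an amine nitrogen gives the first step beyond the scatter in this series, in this assay: an at least 2.5-fold higher number from compound 1 to compound 3 (0.41 log units; beyond the scatter). Compound 1 and compound 2 lie within the scatter of each other, so they gave no such separation. Compound 3 gives > 4000 nM, a limit and not a number: the limit of > 4000 nM in this assay, at which 1 of the 3 values shown sits.

The compounds shown change ring size and aromatic character together, so neither can be singled out as the source of the step. A cyclohexyl group on the same nitrogen would separate the two, and a benzyl group would test a carbon spacer before the aromatic ring.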